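Working notes: from 2-bromophenyl to 4-nitrophenyl

A few compounds are considered here, and "the series" means these few. Any claim that something is new, unique, unknown or untested is made for them only; others in the source may bear on it.

Measured in a functional assay on MCF7 cells (Homo sapiens) for cytotoxicity, read by MTT assay, with a stated time of 96 h; on this read-out lower numbers stand for stronger inhibition and higher numbers for weaker inhibition:
- compound 1 `COc1cc(C(=O)c2cn(-c3ccccc3)cc2-c2ccc(N)cc2)cc(OC)c1OC`: 9 nM
- compound 2 `COc1cc(C(=O)c2cn(-c3ccccc3)cc2-c2ccccc2C)cc(OC)c1OC`: 190 nM
- compound 3 `COc1cc(C(=O)c2cn(-c3ccccc3)cc2-c2ccccc2Br)cc(OC)c1OC`: 190 nM

Compound 3 shares the highest number of the three with compound 2, and bromo in place of methyl gave no change at the digits printed from compound 2 to compound 3 (within the scatter). The next structure is compound 4 `COc1cc(C(=O)c2cn(-c3ccccc3)cc2-c2ccc([N+](=O)[O-])cc2)cc(OC)c1OC`, with 4-nitrophenyl in place of 2-bromophenyl on an aromatic carbon.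

Within the data shown here, no measured step introduces 4-nitrophenyl. The nearest evidence is the pair of large steps away from 4-aminophenyl, a 21-fold higher number from compound 1 to compound 2 (1.32 log units; beyond the scatter) and a 21-fold higher number from compound 1 to compound 3 (1.32 log units; beyond the scatter). Both point to this position mattering in this assay, but three compounds cannot show whether the low number of compound 1 extends to other groups named at the 4 position. A partial return towards compound 1 is therefore expected, with wide uncertainty. The expected change is a 3.2-fold lower number from compound 3 to compound 4 (0.50 log units; beyond the scatter). For compound 4, the estimated value is 60 nM, with an expected range of 12 nM to 300 nM.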

Compound 4, half-maximal inhibitory concentration: 590 nM
The estimate for compound 4 lay 9.8-fold (0.99 log units) below the measured number; the whole stated range lies below it.
By their numbers in this assay, from the lowest: compound 1; then compounds 2 and 3 (each within the scatter of the next); then compound 4.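

In this assay, the 4-substituted phenyl does not by itself keep the low number of compound 1: with nitro in place of amino there is a 66-fold higher number from compound 1 to compound 4 (1.82 log units; beyond the scatter), the largest step among the four compounds, so the group carried on that phenyl strongly changes the read-out. 4-Nitrophenyl also compares unfavourably with both earlier groups: 2-bromophenyl gives a 3.1-fold higher number from compound 3 to compound 4 (0.49 log units; beyond the scatter), and 2-methylphenyl gives a 3.1-fold higher number from compound 2 to compound 4 (0.49 log units; beyond the scatter), leaving compound 4 with the highest number of the four. No available measurement explains these differences.

On these data alone, it remains open whether the low number of compound 1 needs the free amine or would persist with a hydroxyl or methoxy group in its place. 4-Methylphenyl and 4-bromophenyl would separate where the group sits from which group it is, two things that change together from compound 1 to compound 2 and to compound 3.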